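From a heptyl chain to a tert-butoxycarbonyl group

The compounds below may be only part of what the source reports. "The series", "measured", "known", "first", "only" and "open" are said of these compounds alone.

In an ADME assay on J774 cells (Mus musculus) for cytotoxicity (a lower number here means that less compound is needed, a higher number that more compound is needed for the effect), compound 1 (`COc1ccc2c(=O)cc(C)[nH]c2c1`) gives > 52800 nM, which is a limit of the assay. Compound 2 (`Cc1[nH]c2ccccc2c(=O)c1Br`) gives > 42000 nM, also a limit. Compound 3 (`CCCCCCC/C=C/c1c(C)[nH]c2ccccc2c1=O`) alone has an actual number, 28000 nM. Compound 4 (`Cc1[nH]c2ccccc2c(=O)c1/C=C/C(=O)OC(C)(C)C`) has tert-butoxycarbonyl in place of heptyl on a double-bonded chain carbon bound to a double-bonded chain carbon. Going by the values given here, no measured pair shows this change directly. Compound 3 gives the starting value, and the two limits of the compounds without the heptyl suggest that any shift will be upward. In this assay a small rise, no larger than the scatter, is therefore expected: a 1.6-fold higher number from compound 3 to compound 4 (0.21 log units; within the scatter). For compound 4 the estimated value is 45000 nM, with an expected range of 20000 nM to 90000 nM.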

Compound 4, half-maximal effective concentration: > 40000 nM
Compound 4: a limit, no number (the forecaster's own chance of this, stated with the estimate: 50%); the middle value does not contradict the limit.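

In this assay compound 4 gives > 40000 nM, which is a limit of the assay and not a number: the limit of > 40000 nM in this assay, at which 1 of the 4 values shown sits. Swapping the chain on this double-bonded chain carbon gives an at least 1.4-fold higher number from compound 3 to compound 4 (0.15 log units; that floor lies within the scatter), so only a floor can be read, and a real rise is neither shown nor ruled out. Going by these compounds alone, compound 3 thus remains the only compound with an actual number, and this is the first step that can be read at this position. Still open, on these data alone, is how far compound 4 lies beyond its limit, and whether a carboxylic acid or a shorter alkyl chain in this place would give a number at all.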